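The source may hold more compounds than are shown below. What is called first, only, known or untested is meant among the compounds shown, and "the series" means these compounds.

Compound 1 `O=C(O)c1cnc(Oc2ccc3c(c2)B(O)OC3)cn1` carries a free carboxylic acid on the shared core. In an ADME assay on Jurkat cells (Homo sapiens) for cytotoxicity, read by MTT assay, with a stated time of 72 h (a lower number here means a stronger inhibitor, a higher number a weaker inhibitor), compound 1 reaches only the limit of the assay at > 100000 nM, so no number is known for it, only that it sits at the limit of > 100000 nM in this assay, at which 1 of the 2 values shown sits. Its measured neighbour, compound 2 `COC(=O)c1cnc(Oc2ccc3c(c2)B(O)OC3)cn1`, replaces that acid hydrogen with a methyl, and in this assay compound 2 gives 7590 nM, which is an at least 13-fold lower number from compound 1 to compound 2 (1.11 log units; beyond the scatter). The compound now in question, compound 3 `CC(C)COC(=O)c1cnc(Oc2ccc3c(c2)B(O)OC3)cn1`, differs from compound 1 by isobutyl in place of hydrogen on an oxygen next to a carbonyl group. For the measured compounds named here, the only step that bears on it is the one from compound 1 to compound 2, a large one, and compound 3 makes a change of the same kind at the same place with a longer ester. Compound 3 is therefore expected to show a step of roughly an at least 25-fold lower number from compound 1 to compound 3 (1.39 log units; beyond the scatter), and its estimated value in this assay is 4000 nM, within 1500 nM to 15000 nM.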

Compound 3, half-maximal inhibitory concentration: 17600 nM
Compound 3: the middle estimate sits 4.4-fold (0.64 log units) below what was measured; the measured number lies above the stated range.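

In this assay, the step with isobutyl on this oxygen is an at least 5.6-fold lower number from compound 1 to compound 3 (0.75 log units; beyond the scatter), so replacing the acid hydrogen lowers the number with this longer ester as well as with the methyl. Extending the ester does not take that drop further, however: the change at the saturated chain carbon gives a 2.3-fold higher number from compound 2 to compound 3 (0.37 log units; beyond the scatter), and the methyl ester of compound 2 remains the better-placed of the two esters for a low number. As far as these compounds go, the size of both steps from compound 1 stays open-ended, as its entry is a limit and not a number: the limit of > 100000 nM in this assay, at which 1 of the 3 values shown sits.

The compounds shown leave open whether the number keeps rising along the ester chain, since only methyl and isobutyl stand here, with nothing such as an ethyl or a longer straight chain between or beyond them. They also leave open how an amide or a benzyl ester would fare at this place.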